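A few compounds are considered here, and "the series" means these few. Any claim that something is new, unique, unknown or untested is made for them only; others in the source may bear on it.

Measured compounds:
Compound 1 `COc1ccc(-c2ccc3c(c2)C(=O)C(=O)N3C)cc1` gives 6670 nM in a functional assay on HepG2 cells (Homo sapiens) for antiproliferative activity, read by MTT assay, with a stated time of 48 h; a higher number here means a weaker inhibitor, a lower number a stronger inhibitor.
Compound 2 `COc1ccc(-c2ccc3c(c2)C(=O)C(=O)N3Cc2ccc(C)cc2)cc1` gives 330 nM in this assay.

Compound 2 holds the lowest number of the two measured in this assay; its nearest neighbour is compound 1, whose value lies a long way higher. Going by the values given here, the single measured step that joins them, a 20-fold lower number from compound 1 to compound 2 (1.31 log units; beyond the scatter), is large and comes from placing an aromatic ring on the saturated chain carbon bound to the amide-type nitrogen in the ring, where compound 1 carries only hydrogen.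

Compound 3 `COc1ccc(-c2ccc3c(c2)C(=O)C(=O)N3Cc2ccc3ccccc3c2)cc1` has not yet been measured in this assay. It differs from compound 2 by naphthalen-2-yl in place of 4-methylphenyl on a saturated chain carbon bound to an amide-type nitrogen in a ring. Among the compounds with values here, no measured pair varies this group while the attachment stays aromatic, so the only step that bears on it is the one from compound 1 to compound 2, which shows that an aromatic group at this place is well tolerated and strongly favoured over hydrogen. Enlarging that group to a second fused ring is expected to leave the number near that of compound 2, with a step of a 1.3-fold lower number from compound 2 to compound 3 (0.12 log units; within the scatter) that does not clearly exceed the scatter; compound 3 is therefore estimated at 250 nM, between 80 nM and 800 nM.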

Compound 3, half-maximal inhibitory concentration: 380 nM
Estimate against measurement, compound 3: 1.5-fold (0.18 log units) below; measured number inside the range.
By their numbers in this assay, from the lowest: compounds 2 and 3 (each within the scatter of the next); then compound 1.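

In this assay, exchanging 4-methylphenyl for naphthalen-2-yl on a saturated chain carbon bound to an amide-type nitrogen in a ring gives a 1.2-fold higher number from compound 2 to compound 3 (0.06 log units; within the scatter), so a second fused aromatic ring at this place does not separate the two compounds. Measured against hydrogen, naphthalen-2-yl gives an 18-fold lower number from compound 1 to compound 3 (1.24 log units; beyond the scatter), which shows that the large gain seen with 4-methylphenyl is not confined to that one group and holds for both aromatic groups shown here. Nothing measured alongside these numbers explains why the two aromatic groups perform alike or why either outdoes hydrogen.

On these data alone, both groups at this place are aromatic rings of carbon only, so it remains open whether the gain over hydrogen requires an aromatic ring at all, or whether a cyclohexyl group, a pyridine ring, or a longer chain ending in an amine or a carboxylic acid would serve as well. The rest of the core is the same in all three compounds, so it is also unknown whether this position would behave in the same way on a different core.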